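This account rests on a few compounds, and the source may have more. Where it says the series, first, only, none or still open, it means among the compounds named here.

For the measured compounds named here, compound 2 `CCC(C)(C)Cc1c[nH]c(CCc2ccc(-c3ccc(F)cn3)cc2)n1` is one of three compounds measured in a functional assay on HEK293 cells for agonist activity at Bombesin receptor subtype-3 (Homo sapiens), read by luminescence and calcium flux, with a stated time of 10 min (on this read-out lower numbers stand for an effect already at smaller amounts and higher numbers for an effect only at larger amounts of compound), where compound 2 gives 97 nM. Its number sits in the middle of the three, but the spread is small: compound 3 `c1ccc(-c2ccc(CCc3nc(CC4CCCC4)c[nH]3)cc2)nc1` gives 98 nM, and compound 1 `CCC(C)(C)Cc1c[nH]c(CCc2ccc(-n3ncnn3)cc2)n1` gives 89 nM, so all three lie within the usual scatter of one another. Compound 4 `CCC(C)(C)Cc1c[nH]c(CCc2ccc(-c3ccns3)cc2)n1` has not yet been measured. It differs from compound 2 in one place: 1,2-thiazol-5-yl in place of 5-fluoropyridin-2-yl on an aromatic carbon. Going by the values given here, the only measured step that bears on this is the one from compound 1 to compound 2, which also exchanged the group at this same place, 2H-tetrazol-2-yl for 5-fluoropyridin-2-yl, and gave a 1.1-fold higher number from compound 1 to compound 2 (0.04 log units; within the scatter). Here the 5-fluoropyridin-2-yl leaves again, in favour of 1,2-thiazol-5-yl, and on that single precedent no step beyond the scatter is expected, so the change from compound 2 to compound 4 is estimated at a 1.0-fold higher number from compound 2 to compound 4 (0.01 log units; within the scatter). Compound 4 is therefore expected to give about 100 nM in this assay, most likely between 40 nM and 260 nM.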

Compound 4, half-maximal effective concentration: 102 nM
The estimate for compound 4 lay 1.0-fold (0.01 log units) below the measured number, and the stated range covers the measured number.
By their numbers in this assay, from the lowest: compounds 1, 2, 3 and 4 (each within the scatter of the next).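

In this assay, 1,2-thiazol-5-yl in place of 5-fluoropyridin-2-yl gives a 1.1-fold higher number from compound 2 to compound 4 (0.02 log units; within the scatter), and in place of 2H-tetrazol-2-yl it gives a 1.1-fold higher number from compound 1 to compound 4 (0.06 log units; within the scatter). For the compounds shown here, this position, on an aromatic carbon para to a large group, now carries three different aromatic groups, including one with sulfur in a five-membered ring and fewer heavy atoms than 5-fluoropyridin-2-yl, and no step among them goes beyond the scatter. No measurement shown here explains why these groups read alike.

The compounds shown do not tell how an amine, a carboxylic acid or a longer alkyl chain at this place would read. They also leave open whether any group here could move the number beyond the scatter at all.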